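A few compounds are considered here, and "the series" means these few. Any claim that something is new, unique, unknown or untested is made for them only; others in the source may bear on it.

Measured so far:
compound 1 `N#CCCCN(Cc1ccccc1)Cc1ccc2ccccc2c1` – 0%
compound 2 `c1ccc(CN(Cc2ccc3ccccc3c2)c2cccnc2)cc1` – 0%

Both were tested in an assay on HEK293 cells for binding affinity to Substance-K receptor (Rattus norvegicus), read by FRET, tested at 10 uM; on this read-out higher numbers stand for more inhibition at the one concentration tested (going by the name of the read-out) and lower numbers for less inhibition. Going by the values given here, compound 2 stands level with compound 1: the one measured step, no change at the digits printed from compound 1 to compound 2 (within the scatter), swaps a chain for a ring on the amine nitrogen and leaves the read-out where it was. Neither compound shows any inhibition worth noting.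

Compound 3 `c1ccc(CN(Cc2ccc3ccccc3c2)c2ccccn2)cc1` is the next candidate. Its difference from compound 2 is small: pyridin-2-yl in place of pyridin-3-yl on an amine nitrogen. Among the compounds with values here, no measured step covers a move of one ring nitrogen to another position; the only step on record, no change at the digits printed from compound 1 to compound 2 (within the scatter), concerns a larger change and was flat. With both measured compounds sitting at the bottom of the scale and the new change modest, the expected step of a number 3 percentage points higher from compound 2 to compound 3 (within the scatter) is none beyond the scatter. Compound 3 is therefore estimated at 3%, within a range of -8% to 18%.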

Compound 3, a percentage reported as inhibition, at one concentration (the size of the read-out at that concentration, not a potency): 17%
Beside the measured number, compound 3's estimate is 14 percentage points below it; low and high end bracket the measured number.
By their numbers in this assay, from the lowest: compounds 1 and 2 (each within the scatter of the next); then compound 3.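

In this assay, this place on the amine nitrogen responds to where the ring nitrogen of the pyridine sits: the two groups have the same atoms and the same counts, yet pyridin-2-yl in place of pyridin-3-yl gives a number 17 percentage points higher from compound 2 to compound 3 (beyond the scatter). Measured against the 3-cyanopropyl chain, pyridin-2-yl gives a number 17 percentage points higher from compound 1 to compound 3 (beyond the scatter), while pyridin-3-yl gave no change at the digits printed from compound 1 to compound 2 (within the scatter), so among these three compounds, having a pyridine ring at this place is not enough on its own to raise the read-out. Nothing measured here accounts for the difference between the two pyridine groups.

Going by these compounds, it remains open whether a plain phenyl ring or a pyrimidine ring at the same place would raise the inhibition further or lose it. Also open, on these data alone, is whether the gain from pyridin-2-yl would hold if the benzyl group on the same nitrogen were replaced by a longer chain.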